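Cyclohexyl in place of neopentyl: working notes

The source may hold more compounds than are shown below. What is called first, only, known or untested is meant among the compounds shown, and "the series" means these compounds.

- compound 1 `O=C(NCc1cc(Cl)ccc1-n1cnnn1)[C@@H]1[C@H]2C[C@H]2CN1C(=O)[C@H](O)c1ccccc1`: 12 10^-6 cm/s
- compound 2 `CC(C)(C)C[C@@H](O)C(=O)N1C[C@@H]2C[C@@H]2[C@H]1C(=O)NCc1cc(Cl)ccc1-n1cnnn1`: 25 10^-6 cm/s

In an ADME assay on Caco-2 cells (Homo sapiens) for permeability, read by LC-MS, in the apical to basolateral direction, with a stated time of 60 min, at pH 6.5 (a lower number here means that the compound crosses the layer more slowly, a higher number that the compound crosses the layer faster), compound 2 has the higher of the two numbers, at 25 10^-6 cm/s. The next analogue is compound 3 `O=C(NCc1cc(Cl)ccc1-n1cnnn1)[C@@H]1[C@H]2C[C@H]2CN1C(=O)[C@H](O)C1CCCCC1`, and the change is cyclohexyl in place of neopentyl on a saturated chain carbon bound to a carbonyl carbon and an oxygen on a saturated carbon. For the measured compounds named here, the only measured step at this place is a 2.1-fold higher number from compound 1 to compound 2 (0.32 log units; beyond the scatter), which is modest. It gives no direct reading for a cyclohexyl group, so only a small change is expected, with no step beyond the scatter. The expected step is a 1.3-fold lower number from compound 2 to compound 3 (0.10 log units; within the scatter). For compound 3 the estimated value is 20 10^-6 cm/s, with an expected range from 10 10^-6 cm/s to 38 10^-6 cm/s.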

Compound 3, apparent permeability: 25 10^-6 cm/s
Beside the measured number, compound 3's estimate is 1.3-fold (0.10 log units) below it, and the stated range covers the measured number.
By their numbers in this assay, from the lowest: compound 1; then compounds 2 and 3 (each within the scatter of the next).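

In this assay, cyclohexyl in place of neopentyl gives no change at the digits printed from compound 2 to compound 3 (within the scatter) and so leaves the number unmoved at this position, whether the saturated carbon group is a ring or an open chain. Cyclohexyl in place of phenyl gives a 2.1-fold higher number from compound 1 to compound 3 (0.32 log units; beyond the scatter) and matches the earlier neopentyl step, which leaves compound 1 apart from compounds 2 and 3. No evidence on hand bears on this result.

Still open, on these data alone, is whether this level holds for a saturated group carrying an amine or a carboxylic acid. As far as these compounds go, a shorter chain such as methyl also remains untested in these compounds.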